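A few compounds are considered here, and "the series" means these few. Any claim that something is new, unique, unknown or untested is made for them only; others in the source may bear on it.

Compound 3 `O=C(COc1cccc2ccccc12)N/N=C/c1ccccc1` is the member with an unsubstituted phenyl on the carbon double-bonded to nitrogen; in an ADME assay on HEL cells (Homo sapiens) for cytotoxicity (a higher number here means that more compound is tolerated, a lower number that less compound is tolerated), compound 3 gives 100 ug/mL. Compound 1 `O=C(COc1cccc2ccccc12)N/N=C/c1ccc(Cl)cc1` gives 100 ug/mL and compound 2 `O=C(COc1cccc2ccccc12)N/N=C/c1cccc(O)c1` gives 100 ug/mL, so compound 3 stands level with both: no change at the digits printed from compound 1 to compound 3 (within the scatter) and no change at the digits printed from compound 2 to compound 3 (within the scatter). Compound 4 `O=C(COc1cccc2ccccc12)N/N=C/c1cccc(Cl)c1` carries chloro in place of hydrogen on an aromatic carbon. The step bearing most directly on this is the removal of chloro, no change at the digits printed from compound 1 to compound 3 (within the scatter), which is flat; no change at the digits printed from compound 1 to compound 2 (within the scatter) is flat as well. Three variations on this aromatic ring leave the minimum cytotoxic concentration unchanged, so no step beyond the scatter is expected in this assay, and no change at the digits printed from compound 3 to compound 4 (within the scatter) is expected to be flat. Compound 4 is estimated at 100 ug/mL, with a range of 50 ug/mL to 200 ug/mL.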

Compound 4, minimum cytotoxic concentration: 100 ug/mL
For compound 4 middle estimate and measured number coincide at the digits printed; low and high end bracket the measured number.
By their numbers in this assay, from the lowest: compounds 1, 2, 3 and 4 (each within the scatter of the next).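

In this assay chloro on an aromatic carbon, meta to a large group, gives no change at the digits printed from compound 3 to compound 4 (within the scatter) and so adds a chloro reading at this position to the hydrogen one. With 3-chlorophenyl in place of 4-chlorophenyl the result is no change at the digits printed from compound 1 to compound 4 (within the scatter) and with chloro in place of hydroxy it is no change at the digits printed from compound 2 to compound 4 (within the scatter), so all four ring variants read alike. No measured evidence bears on this flat result.

On these data alone, an amine, a carboxylic acid or a longer chain at this ring position remains open. So does whether any change to the shared core would move the minimum cytotoxic concentration.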